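The source may hold more compounds than are shown below. What is called first, only, known or untested is meant among the compounds shown, and "the series" means these compounds.

Compound 3 `Cc1c(C)c2c(c(C)c1OC(=O)CCC(=O)O)CCC(C)(C(=O)NCC1CC(C)(C)N([O])C1(C)C)O2` shares its core with compound 1 `Cc1c(C)c2c(c(C)c1OC(=O)CCC(=O)O)CCC(C)(C(=O)NC1CC(C)(C)N([O])C1(C)C)O2` and compound 2 `Cc1c(C)c2c(c(C)c1OC(=O)CCC(=O)NCC1CC(C)(C)N([O])C1(C)C)CCC(C)(C(=O)NCC1CC(C)(C)N([O])C1(C)C)O2`. In a functional assay on HepG2 cells (Homo sapiens) for cytotoxicity, read by MTT assay, with a stated time of 72 h (on this read-out lower numbers stand for stronger inhibition and higher numbers for weaker inhibition), compound 3 gives only the limit > 300000 nM. Compound 1 likewise stops at the limit > 300000 nM. Compound 2 reaches a number, 176000 nM. The step that the two limits leave unreadable from compound 1 to compound 3 therefore cannot be sized, and the step of an at least 1.7-fold higher number from compound 2 to compound 3 (0.23 log units; that floor lies within the scatter) rests on (the limit of > 300000 nM in this assay, at which 2 of the 3 values shown sit). Compound 4 `Cc1c(C)c2c(c(C)c1O)CCC(C)(C(=O)NCC1CC(C)(C)N([O])C1(C)C)O2` differs from compound 3 by hydrogen in place of (2-carboxyethyl)carbonyl on an oxygen on an aromatic ring. Among the measured compounds shown here, no measured step touches this change, and the one readable step is within the scatter, so no movement in this assay beyond the scatter is expected from the data at hand. Compound 4 is accordingly expected near 220000 nM, within 70000 nM to 300000 nM, which means an expected step of an at least 1.3-fold lower number from compound 3 to compound 4 (0.13 log units; that floor lies within the scatter).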

Compound 4, half-maximal inhibitory concentration: > 300000 nM
Compound 4 was reported as a limit (the forecaster's own chance of this, stated with the estimate: 55%); middle value at least 1.3-fold (0.13 log units) away from the limit.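

Compound 3 and compound 4 both stop at a limit in this assay, so no step between them can be read: the limit of > 300000 nM in this assay, at which 3 of the 4 values shown sit.

The compounds shown leave open whether the change from ((2-carboxyethyl)carbonyl)oxy to hydroxy moves the read-out at all.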